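Fluorine on the terminal phenyl of the urea series

The source may report more compounds than this note shows. Statements on the series, on what has been measured and on what is new or still open speak of the compounds shown alone.

Compound 2 `CN(C)CCNc1nc(-c2ccc(NC(=O)Nc3ccccc3)cc2)nc2ccsc12` is one of two measured members of the series. In a functional assay on NCI-H460 cells (Homo sapiens) for cytotoxicity, read by MTT assay, with a stated time of 72 h (a lower number here means a stronger inhibitor, a higher number a weaker inhibitor), compound 2 gives 640 nM, the higher of the two numbers; compound 1 `CN(C)CCCNc1nc(-c2ccc(NC(=O)Nc3ccccc3F)cc2)nc2ccsc12` gives 530 nM in this assay, and the two values lie within the scatter of each other, so no order between them is claimed. Among the measured compounds shown here, compound 1 differs from compound 2 in more than one place, and no single step between them is drawn.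

Compound 3 `CN(C)CCNc1nc(-c2ccc(NC(=O)Nc3ccc(F)cc3)cc2)nc2ccsc12` differs from compound 2 by fluoro in place of hydrogen on an aromatic carbon. Nothing measured in the series isolates this change. For the measured compounds named here, with only two values in hand and both close together, no step beyond the scatter is expected from compound 2 to compound 3 in this assay, in either direction. Compound 3 is therefore estimated at 500 nM, with a range of 200 nM to 1500 nM, which means an expected step of a 1.3-fold lower number from compound 2 to compound 3 (0.11 log units; within the scatter).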

Compound 3, half-maximal inhibitory concentration: 390 nM
Compound 3: the middle estimate sits 1.3-fold (0.11 log units) above what was measured; the measured number falls inside the stated range.
By their numbers in this assay, from the lowest: compounds 3, 1 and 2 (each within the scatter of the next).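

Phenyl to 4-fluorophenyl on the urea is the first single change in the series that can be read: in this assay the step is a 1.6-fold lower number from compound 2 to compound 3 (0.22 log units; within the scatter), so no order between the two compounds is claimed. At this carbon, para to a large group, the measured pair therefore gives fluoro and hydrogen as values within the scatter of each other, and this holds for this one substituent and this one assay only. Nothing on hand speaks to a cause for this result.

As far as these compounds go, whether a larger group on the same carbon, such as methoxy, trifluoromethyl or a carboxylic acid, would give a step beyond the scatter remains open. Compound 1 differs from compound 3 in more than one place, so the effect of fluoro elsewhere on that ring cannot be read on its own.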